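The source may report more compounds than this note shows. Statements on the series, on what has been measured and on what is new or still open speak of the compounds shown alone.

Measured compounds in a functional assay on LS174T cells (Homo sapiens) for inhibition, with a stated time of 4 days, tested at 10 uM; on this read-out higher numbers stand for a stronger effect at the one concentration tested and lower numbers for a weaker effect:
- compound 1 `CN(C)c1ccc(C#Cc2c(F)cccc2F)nc1`, 85.2%
- compound 2 `Fc1cccc(F)c1C#Cc1cnc(Cl)c2ccccc12`, 94%
- compound 3 `Nc1ncc(C#Cc2c(F)cccc2F)c2ccccc12`, 93.1%

Compound 3 stands second of the three numbers in this assay. Among the measured compounds shown here, its nearest neighbour is compound 2, which gives 94%; the single step that changes one place, a number 0.9 percentage points lower from compound 2 to compound 3 (within the scatter), lies within the scatter. Compound 1 gives 85.2%, and this gap to compound 3 is likewise within the scatter, so the three numbers cannot be ordered.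

Compound 4 `CNc1ncc(C#Cc2c(F)cccc2F)c2ccccc12` is not yet measured. It differs from compound 3 in one place: methyl in place of hydrogen on a nitrogen on an aromatic ring. For the measured compounds named here, no measured step changes the substituent on that nitrogen; the only measured step replaces chloro by amino on an aromatic carbon and is small, so nothing in the data points to a direction for the step from compound 3 to compound 4 in this assay.

The expectation is therefore a step within the scatter, a number 3.1 percentage points lower from compound 3 to compound 4 (within the scatter), and compound 4 is estimated at 90%, with a range from 75% to 97%.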

Compound 4, a percentage reported as inhibition, at one concentration (the size of the read-out at that concentration, not a potency): 98.9%
Compound 4: middle estimate off by 8.9 percentage points, on the low side, outside the stated range (above it).
By their numbers in this assay, from the lowest: compounds 1, 3, 2 and 4 (each within the scatter of the next, the first and the last beyond it).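

In this assay, among the compounds shown here, the first change at the substituent on this nitrogen, amino to methylamino, gives a number 5.8 percentage points higher from compound 3 to compound 4 (within the scatter) and so shows that methyl in place of hydrogen there leaves the read-out within the scatter. Methylamino in place of chloro on the aromatic carbon gives a number 4.9 percentage points higher from compound 2 to compound 4 (within the scatter), so chloro, amino and methylamino at this place cannot be told apart at the one concentration tested. No measurement at hand accounts for these numbers.

Open, from the compounds shown here alone, is whether a longer chain on this nitrogen, such as ethyl or propyl, or an acetyl group in place of methyl, stays within the scatter of compound 4 in this assay. Also open, going by these compounds, is whether chloro, amino and methylamino would separate into a stronger and a weaker effect at a concentration other than the one tested.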